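Enone direction in a dimethoxyphenyl-pyrazolopyrimidine chalcone series

The source may hold more compounds than are shown below. What is called first, only, known or untested is meant among the compounds shown, and "the series" means these compounds.

Measured so far in a functional assay on MDA-MB-231 cells (Homo sapiens) for antiproliferative activity, read by MTT assay, with a stated time of 24 h; a lower number here means a stronger inhibitor, a higher number a weaker inhibitor:
compound 1 `COc1ccc(-c2cc(/C=C/C(=O)c3cc(OC)c(OC)c(OC)c3)nc3cc(-c4ccccc4)nn23)cc1OC`, 4700 nM
compound 2 `COc1ccc(-c2cc(C(=O)/C=C/c3cc(OC)c(OC)c(OC)c3)nc3cc(-c4ccccc4)nn23)cc1OC`, 16700 nM
compound 3 `COc1ccc(-c2cc(/C=C/C(=O)c3ccccc3)nc3cc(-c4ccccc4)nn23)cc1OC`, 11800 nM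

Compound 3 stands second highest of the three numbers; compound 2 is within the scatter of it, compound 1 beyond it. The step to compound 3 was a 2.5-fold higher number from compound 1 to compound 3 (0.40 log units; beyond the scatter). Compound 4 `COc1ccc(-c2cc(C(=O)/C=C/c3ccccc3)nc3cc(-c4ccccc4)nn23)cc1OC` has the same atoms as compound 3, joined differently: (2-phenylethenyl)carbonyl in place of 2-benzoylethenyl on an aromatic carbon. Within the data shown here, no step of this kind is tabulated, but compound 1 and compound 2 differ in the same way, and compound 2 shows the higher number of the two. On that basis a step of similar sense is expected, a 2.5-fold higher number from compound 3 to compound 4 (0.41 log units; beyond the scatter), though on a single pair its size is uncertain. Compound 4 is therefore estimated at 30000 nM, range 12000 nM to 75000 nM.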

Compound 4, half-maximal inhibitory concentration: 23300 nM
For compound 4 the middle estimate is 1.3-fold (0.11 log units) above the measured one, and the stated range covers the measured number.
By their numbers in this assay, from the lowest: compound 1; then compounds 3, 2 and 4 (each within the scatter of the next).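

In this assay, reversing the enone on the unsubstituted phenyl series gives a 2.0-fold higher number from compound 3 to compound 4 (0.30 log units; within the scatter), the same sense as the printed numbers of compound 1 and compound 2 but not resolved from the scatter. With the reversed enone, phenyl in place of 3,4,5-trimethoxyphenyl gives a 1.4-fold higher number from compound 2 to compound 4 (0.14 log units; within the scatter), so that change is resolved only with the 2-benzoylethenyl direction, yet the two steps themselves cannot be told apart: the same change on two cores in this assay, a 2.5-fold higher number (0.40 log units; beyond the scatter) from compound 1 to compound 3 and a 1.4-fold higher number (0.14 log units; within the scatter) from compound 2 to compound 4, 1.8-fold (0.26 log units) apart, within the scatter of two such steps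

Still open is whether the enone is needed at all, since a saturated chain in its place is not among these compounds. On these data alone, the effect of an amine on the terminal ring also remains open.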